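This account rests on a few compounds, and the source may have more. Where it says the series, first, only, none or still open, it means among the compounds named here.

In a physicochemical assay for solubility, at pH 7.4 (on this read-out lower numbers stand for lower solubility and higher numbers for higher solubility), compound 3 `O=C(CC1CCNCC1)N1CCC(NS(=O)(=O)c2cc(S(=O)(=O)c3ccccc3)ccc2C(F)(F)F)CC1` gives > 100000 nM, which is a limit of the assay and not a number. Compound 1 `O=C(c1cccnc1)N1CCC(NS(=O)(=O)c2cc(S(=O)(=O)c3ccccc3)ccc2C(F)(F)F)CC1` reads 78000 nM, and compound 2 `CN(C)c1ccc(C(=O)N2CCC(NS(=O)(=O)c3cc(S(=O)(=O)c4ccccc4)ccc3C(F)(F)F)CC2)cn1` reads 6700 nM. Compound 4 `O=C([C@@H]1CCNC1)N1CCC(NS(=O)(=O)c2cc(S(=O)(=O)c3ccccc3)ccc2C(F)(F)F)CC1` carries pyrrolidin-3-yl in place of (piperidin-4-yl)methyl on the carbonyl carbon (pyrrolidin-3-yl in place of (piperidin-4-yl)methyl on a carbonyl carbon). Two measured changes at that carbonyl carbon bear on this: an at least 1.2-fold higher number from compound 1 to compound 3 (0.10 log units; that floor lies within the scatter), and an at least 14-fold higher number from compound 2 to compound 3 (1.17 log units; beyond the scatter). Both start from a pyridin-3-yl group, whereas this change exchanges one non-aromatic ring for another, so no step beyond the scatter is expected in this assay. The expected step is an at least 1.1-fold lower number from compound 3 to compound 4 (0.04 log units; that floor lies within the scatter). For compound 4 the estimate is 90000 nM, with an expected range of 40000 nM to 100000 nM.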

Compound 4, solubility: 70000 nM
The estimate for compound 4 lay 1.3-fold (0.11 log units) above the measured number, and the stated range covers the measured number.
By their numbers in this assay, from the lowest: compound 2; then compounds 4 and 1 (each within the scatter of the next). At a limit, above all of these: compound 3.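

In this assay, a non-aromatic ring on this carbonyl carbon now has a measured number and not only a limit, and the change reads as an at least 1.4-fold lower number from compound 3 to compound 4 (0.15 log units; that floor lies within the scatter). That step is only a floor, since compound 3 stands at a limit of the assay: the limit of > 100000 nM in this assay, at which 1 of the 4 values shown sits. Pyrrolidin-3-yl and pyridin-3-yl do not separate here, with a 1.1-fold lower number from compound 1 to compound 4 (0.05 log units; within the scatter), while 6-(dimethylamino)pyridin-3-yl stays apart, with a 10-fold higher number from compound 2 to compound 4 (1.02 log units; beyond the scatter).

Still open, from the compounds shown here alone, are the opposite stereoisomer of pyrrolidin-3-yl and how a carboxylic acid or an open-chain amine on this carbonyl carbon would read in this assay.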